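Truncating the ketone side chain of compound 1

The source may hold more compounds than are shown below. What is called first, only, known or untested is meant among the compounds shown, and "the series" means these compounds.

Measured so far:
- compound 1, `CCC(C(=O)N[C@@H](CC(=O)O)C(=O)CNCN1CCCCC1)n1cc(C(C)(C)C)nc(NCc2nonc2C)c1=O`: 0.29 nM
- compound 2, `CCCCCCN(C)CNCC(=O)[C@H](CC(=O)O)NC(=O)C(CC)n1cc(CC)nc(NCc2nonc2C)c1=O`: 0.078 nM
- compound 3, `CCC(C(=O)N[C@@H](CC(=O)O)C(=O)CSCc1ccccc1)n1ccnc(NCc2nc(C)no2)c1=O`: 5.33 nM

In a functional assay on NT2 cells (Homo sapiens) for inhibition (on this read-out higher numbers stand for weaker inhibition and lower numbers for stronger inhibition), compound 1 gives 0.29 nM, the second highest of the three numbers. Compound 2 sits lower, beyond the scatter, and compound 3 sits higher, also beyond the scatter; neither pair differs in a single place, so only the values themselves are compared here.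

Compound 4, `CCC(C(=O)N[C@@H](CC(=O)O)C(C)=O)n1cc(C(C)(C)C)nc(NCc2nonc2C)c1=O`, is not yet measured. It differs from compound 1 in one place: hydrogen in place of ((piperidin-1-yl)methyl)amino on a saturated chain carbon bound to a carbonyl carbon. For the measured compounds named here, the change is a plain removal, and no pair of measured compounds shows a step of this kind.

On the shared core the expectation is that compound 4 inhibits more weakly than compound 1, with a step of a 17-fold higher number from compound 1 to compound 4 (1.24 log units; beyond the scatter) that is expected to lie beyond the scatter. Going by the values given here, the estimate for compound 4 in this assay is 5 nM, with a range from 0.5 nM to 50 nM; the range is wide since no measured pair supports the size of this step.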

Compound 4, half-maximal inhibitory concentration: 5.12 nM
The estimate for compound 4 lay 1.0-fold (0.01 log units) below the measured number; the range from low to high includes it.
By their numbers in this assay, from the lowest: compound 2; then compound 1; then compounds 4 and 3 (each within the scatter of the next).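

In this assay, for the compounds shown here, replacing ((piperidin-1-yl)methyl)amino with hydrogen on a saturated chain carbon bound to a carbonyl carbon gives an 18-fold higher number from compound 1 to compound 4 (1.25 log units; beyond the scatter) and so provides the first single-place reading: this group, or part of it, counts for much of the inhibition on this core. Inhibition does not vanish with the removal, since compound 4 still gives 5.12 nM and the methyl ketone remains a measurable reference point for this position. Nothing at hand accounts for the size of the step.

Still open, as far as these compounds go, is which part of the removed group carries the difference, the piperidine ring or the amino nitrogen. A simple primary amine, a hydroxyl group or a morpholine ring at the same place on an otherwise unchanged compound 1 would help separate these contributions.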